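From nitro to trifluoromethyl: one swap, one estimate

The source may report more compounds than this note shows. Statements on the series, on what has been measured and on what is new or still open speak of the compounds shown alone.

Compound 1 `O=C1/C(=C/c2cccnc2)CN(S(=O)(=O)c2ccc(C(F)(F)F)cc2)C/C1=C\c1ccccc1F` gives 4500 nM here
Compound 2 `O=C1/C(=C/c2cccnc2)CN(S(=O)(=O)c2ccc([N+](=O)[O-])cc2)C/C1=C\c1ccccc1C(F)(F)F` gives 7660 nM here

In a functional assay on QGY-7703 cells (Homo sapiens) for cytotoxicity, read by MTT assay, with a stated time of 24 h (on this read-out higher numbers stand for weaker inhibition and lower numbers for stronger inhibition), compound 2 stands within the usual scatter of compound 1, so repeat measurements could not reliably tell these two compounds apart. Compound 3 `O=C1/C(=C/c2cccnc2)CN(S(=O)(=O)c2ccc(C(F)(F)F)cc2)C/C1=C\c1ccccc1C(F)(F)F` is compound 2 with one change. The change trifluoromethyl in place of nitro on an aromatic carbon places trifluoromethyl in place of nitro on an aromatic carbon, para to a large group. Among the measured compounds shown here, no measured pair shows this swap on its own, so its effect has not been seen directly. For the measured compounds named here, the only guide is the close pair of values, compound 1 at 4500 nM and compound 2 at 7660 nM on this scale. No step beyond the scatter is therefore expected, in either direction. The estimated step of a 1.3-fold lower number from compound 2 to compound 3 (0.11 log units; within the scatter) stays inside that scatter. In this assay compound 3 is expected at 6000 nM (range 2800 nM to 12000 nM).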

Compound 3, half-maximal inhibitory concentration: 1500 nM
The estimate for compound 3 lay 4.0-fold (0.60 log units) above the measured number, outside the stated range (below it).
By their numbers in this assay, from the lowest: compound 3; then compounds 1 and 2 (each within the scatter of the next).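

Trifluoromethyl in place of nitro on an aromatic carbon, para to a large group, gives a 5.1-fold lower number from compound 2 to compound 3 (0.71 log units; beyond the scatter) in this assay and so makes a real difference at this position. Trifluoromethyl in place of fluoro on an aromatic carbon, the other place where the compounds vary, gives a 3.0-fold lower number from compound 1 to compound 3 (0.48 log units; beyond the scatter) in this assay and counts as a real difference too. Compound 1 and compound 2 differ in two places, so their close values said nothing about either place alone, whereas compound 3 differs from each of them in just one.

As far as these compounds go, how an amine or a carboxylic acid on the same aromatic carbon would compare remains open. Nothing shown explains why either step occurs.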